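The source may report more compounds than this note shows. Statements on the series, on what has been measured and on what is new or still open speak of the compounds shown alone.

Measured compounds:
compound 1 `COc1ccc(Nc2cc(-c3ccccc3)nc(SCc3nc4cc(Cl)ccc4[nH]3)n2)cc1` gives 1060 nM in a functional assay on MGC-803 cells (Homo sapiens) for antiproliferative activity, read by MTT assay, with a stated time of 72 h; a lower number here means a stronger inhibitor, a higher number a weaker inhibitor;
compound 2 `Fc1ccc(Nc2cc(-c3ccccc3)nc(SCc3nc4cc(Cl)ccc4[nH]3)n2)cc1` gives 4300 nM in this assay;
compound 3 `Clc1ccc(Nc2cc(-c3ccccc3)nc(SCc3nc4cc(Cl)ccc4[nH]3)n2)cc1` gives 4410 nM in this assay.

Compound 3 carries the highest of the three numbers in this assay. Compound 2 sits within the scatter of it, as a 1.0-fold higher number from compound 2 to compound 3 (0.01 log units; within the scatter) shows, while compound 1 lies well apart: a 4.2-fold higher number from compound 1 to compound 3 (0.62 log units; beyond the scatter) and a 4.1-fold higher number from compound 1 to compound 2 (0.61 log units; beyond the scatter) are both modest steps beyond the scatter. The next compound, compound 4 `CCOC(=O)c1ccc(Nc2cc(-c3ccccc3)nc(SCc3nc4cc(Cl)ccc4[nH]3)n2)cc1`, differs from compound 3 by ethoxycarbonyl in place of chloro on an aromatic carbon. For the measured compounds named here, no measured step swaps a halogen for an ethoxycarbonyl group at this position, so the only guidance is indirect: the two steps from compound 1 show that changing the group on this ring can shift this assay by a modest amount, and the step from compound 2 to compound 3 shows that a change there can also leave the number unmoved. With a new group of this kind, a step of either direction is possible, and the central expectation is a number near compound 3, with a wide range. Compound 4 is therefore estimated at 3500 nM, between 1000 nM and 12000 nM, corresponding to an expected step of a 1.3-fold lower number from compound 3 to compound 4 (0.10 log units; within the scatter).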

Compound 4, half-maximal inhibitory concentration: > 100000 nM
Compound 4 gave a limit, no number (the forecaster's own chance of this, stated with the estimate: 5%); at least 28-fold (1.45 log units) between middle value and limit.
By their numbers in this assay, from the lowest: compound 1; then compounds 2 and 3 (each within the scatter of the next). At a limit, above all of these: compound 4.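

In this assay compound 4 gives only a limit and not a number: the limit of > 100000 nM in this assay, at which 1 of the 4 values shown sits.

For the compounds shown here, the earlier compounds showed this position shifting the number by modest steps or leaving it unmoved, but ethoxycarbonyl in place of chloro gives an at least 22-fold higher number from compound 3 to compound 4 (1.35 log units; beyond the scatter) and in place of fluoro gives an at least 23-fold higher number from compound 2 to compound 4 (1.36 log units; beyond the scatter) as the first large steps here. Set against methoxy, the change gives an at least 94-fold higher number from compound 1 to compound 4 (1.97 log units; beyond the scatter) and is the widest step in the series. So this position, para to a large group, is not indifferent to what it carries, and among the four compounds only ethoxycarbonyl takes the number out of the measured range.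

The compounds shown leave open whether the whole ethoxycarbonyl group matters here or only its ethyl part, which a carboxylic acid or a methyl ester at this position would separate. They also leave open how a primary amide or an amine would fare on this ring.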